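Swapping pyridazine for thiadiazole on the amide nitrogen

The compounds below may be only part of what the source reports. "The series", "measured", "known", "first", "only" and "open" are said of these compounds alone.

Compound 1 `CC(C)[C@H](C(=O)NCc1ccccc1)c1ccc(Cl)cc1` gives > 100000 nM in a functional assay on CHO cells for agonist activity at Free fatty acid receptor 2 (Homo sapiens), read by cAMP accumulation (on this read-out lower numbers stand for stronger inhibition and higher numbers for weaker inhibition), which is a limit of the assay rather than a number.
Compound 2 `CC(C)[C@H](C(=O)Nc1ccc(F)cn1)c1ccc(Cl)cc1` gives 1300 nM in this assay.
Compound 3 `CC(C)[C@H](C(=O)Nc1cccnn1)c1ccc(Cl)cc1` gives 2300 nM in this assay.

Compound 3 has the highest of the two numbers, though its neighbour compound 2 sits close: a 1.8-fold higher number from compound 2 to compound 3 (0.25 log units; within the scatter). Compound 4 `CC(C)[C@H](C(=O)Nc1nncs1)c1ccc(Cl)cc1` differs from compound 3 by 1,3,4-thiadiazol-2-yl in place of pyridazin-3-yl on an amide-type nitrogen. Two steps show that replacing benzyl by a small aromatic heterocycle on the amide nitrogen matters greatly: an at least 76-fold lower number from compound 1 to compound 2 (1.88 log units; beyond the scatter) and an at least 43-fold lower number from compound 1 to compound 3 (1.63 log units; beyond the scatter). Between two such heterocycles, however, the change was small: a 1.8-fold higher number from compound 2 to compound 3 (0.25 log units; within the scatter). The move to a thiadiazole is expected to behave likewise, giving a 1.1-fold higher number from compound 3 to compound 4 (0.04 log units; within the scatter), a step within the scatter. Compound 4 is therefore estimated at 2500 nM, between 700 nM and 9000 nM.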

Compound 4, half-maximal inhibitory concentration: 12000 nM
Compound 4: middle estimate off by 4.8-fold (0.68 log units), on the low side; measured number outside the range, above it.
By their numbers in this assay, from the lowest: compounds 2 and 3 (each within the scatter of the next); then compound 4. At a limit, above all of these: compound 1.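

Aromatic rings on the amide nitrogen are not interchangeable here: unlike the earlier swap between two such rings, this one moves the number beyond the scatter, with a 5.2-fold higher number from compound 3 to compound 4 (0.72 log units; beyond the scatter) and a 9.2-fold higher number from compound 2 to compound 4 (0.97 log units; beyond the scatter). The 1,3,4-thiadiazol-2-yl group still compares well with benzyl, an at least 8.3-fold lower number from compound 1 to compound 4 (0.92 log units; beyond the scatter), a step that rests on a limit for compound 1. Nothing shown here explains why the number rises with the five-membered ring. As far as these compounds go, it remains open how a methyl group or an amine on the 1,3,4-thiadiazol-2-yl ring would read in this assay.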